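A few compounds are considered here, and "the series" means these few. Any claim that something is new, unique, unknown or untested is made for them only; others in the source may bear on it.

Of the compounds shown here, three of one shared core have been measured in an assay on isolated protein for inhibition of MAP kinase-activated protein kinase 2 (Homo sapiens), read by mobility shift assay, tested at 30 uM; a lower number here means less inhibition, a higher number more inhibition at the concentration tested (going by the name of the read-out). Compound 1 `Cc1cc2[nH]nc(N)c2c(=O)[nH]1` gives 30%, compound 2 `COc1ccc(-c2cc3[nH]nc(N)c3c(=O)[nH]2)cc1` gives 59%, and compound 3 `Cc1cc2nn(-c3ccccc3)c(N)c2c(=O)[nH]1` gives -4%. On these numbers compound 3 stands lowest of the three: the nearest value, that of compound 1, lies beyond the scatter above it, and that of compound 2 lies further still.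

Compound 4 `COc1ccc(-c2cc3nn(-c4ccccc4)c(N)c3c(=O)[nH]2)cc1` has not yet been measured in this assay. Its structure differs from compound 3 in one place: 4-methoxyphenyl in place of methyl on an aromatic carbon.

Within the data shown here, no pair of measured compounds differing in exactly one place is available, so the size of this step is not known from any measured analogue. What compound 1 and compound 2 show is a different pair, carrying the same methyl and 4-methoxyphenyl groups on a core without the phenyl on the ring nitrogen. From that, compound 4 is expected to sit somewhat above compound 3 in this assay, with a step of a number 16 percentage points higher from compound 3 to compound 4 (beyond the scatter), roughly at the edge of the scatter. The estimate for compound 4 is 12%, with a range from -10% to 40%.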

Compound 4, a percentage reported as inhibition, at one concentration (the size of the read-out at that concentration, not a potency): 7%
For compound 4 the middle estimate is 5 percentage points above the measured one; the range from low to high includes it.
By their numbers in this assay, from the lowest: compound 3; then compound 4; then compound 1; then compound 2.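

Among these compounds, measured directly in this assay, the change on this aromatic carbon next to the ring nitrogen gives a number 11 percentage points higher from compound 3 to compound 4 (beyond the scatter) and is the first step at this position read on one core. The step is modest, and the 4-methoxyphenyl group leaves the number low on the core with phenyl on the ring nitrogen: compound 4 gives 7% in this assay while compound 2, without that phenyl, gives 59% in the same assay. Nothing measured here accounts for the size of this step.

On these data alone, whether an unsubstituted phenyl, an amine or a carboxylic acid on this carbon would give a different number remains open. So does the outcome of exchanging the phenyl on the ring nitrogen for a methyl or a longer chain while the 4-methoxyphenyl stays in place.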